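The source may hold more compounds than are shown below. What is called first, only, known or untested is meant among the compounds shown, and "the series" means these compounds.

Compound 1 `COC(=O)C[S+]([O-])CC1CN(C)CCC1c1ccc(Cl)cc1` gives 231 nM in an assay on isolated protein for inhibition of sodium-dependent dopamine transporter (Rattus norvegicus), read by radioligand binding (on this read-out higher numbers stand for weaker inhibition and lower numbers for stronger inhibition), the highest number among the three measured compounds. Compound 2 `COCCSCC1CN(C)CCC1c1ccc(Cl)cc1` gives 50 nM in this assay, and compound 3 `COCC[S+]([O-])CC1CN(C)CCC1c1ccc(Cl)cc1` gives 15 nM. Compound 4 `CC(=O)OCC[S+]([O-])CC1CN(C)CCC1c1ccc(Cl)cc1` differs from compound 1 by acetoxymethyl in place of methoxycarbonyl on a saturated chain carbon bound to a sulfur. The step that bears most directly on this is a 15-fold lower number from compound 1 to compound 3 (1.19 log units; beyond the scatter), which also removed the methoxycarbonyl from that chain carbon; a 4.6-fold lower number from compound 1 to compound 2 (0.66 log units; beyond the scatter) and a 3.3-fold lower number from compound 2 to compound 3 (0.52 log units; beyond the scatter) show how wide the spread within this small set is. Compound 4 keeps an ester, only cut one bond further out as 2-acetoxyethyl, so a gain smaller than a 15-fold lower number from compound 1 to compound 3 (1.19 log units; beyond the scatter) is expected. Compound 4 is therefore estimated at 70 nM, within 25 nM to 200 nM. This expectation amounts to a 3.3-fold lower number from compound 1 to compound 4 (0.52 log units; beyond the scatter).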

Compound 4, inhibition constant: 9 nM
Compound 4: middle estimate off by 7.8-fold (0.89 log units), on the high side; the whole stated range lies above it.
By their numbers in this assay, from the lowest: compounds 4 and 3 (each within the scatter of the next); then compound 2; then compound 1.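

Acetoxymethyl in place of methoxycarbonyl gives a 26-fold lower number from compound 1 to compound 4 (1.41 log units; beyond the scatter) in this assay and shows that, on a saturated chain carbon bound to a sulfur, an ester does not by itself go with the high number of compound 1. Acetyl in place of methyl on the oxygen gives a 1.7-fold lower number from compound 3 to compound 4 (0.22 log units; within the scatter) and leaves the acetate and the methyl ether indistinguishable here. Nothing measured explains why the orientation of the ester should matter.

Still open, going by these compounds, is how a free hydroxyl, an amide or a longer chain would read at this place.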